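Compound 4: adding a methoxy to the fluorophenyl arm

A few compounds are considered here, and "the series" means these few. Any claim that something is new, unique, unknown or untested is made for them only; others in the source may bear on it.

Compound 3 `COc1ccc(C(=O)c2cc(OC)c(OC)c(OC)c2)cc1NC(=O)/C=C/c1ccc(F)cc1` gives the lowest number of the three measured compounds in a functional assay on ME-180 cells (Homo sapiens) for cytotoxicity, read by MTT assay, with a stated time of 72 h (a lower number here means a stronger inhibitor, a higher number a weaker inhibitor), 300 nM. Compound 1 `COc1ccc(C(=O)c2cc(OC)c(OC)c(OC)c2)cc1NC(=O)/C=C/c1ccc(OC)c(OC)c1` gives 8900 nM, and compound 2 `COc1ccc(/C=C/C(=O)Nc2cc(C(=O)c3cc(OC)c(OC)c(OC)c3)ccc2OC)cc1` gives 11800 nM, both beyond the scatter above compound 3. Compound 4 `COc1cc(/C=C/C(=O)Nc2cc(C(=O)c3cc(OC)c(OC)c(OC)c3)ccc2OC)ccc1F` differs from compound 3 by methoxy in place of hydrogen on an aromatic carbon. Among the measured compounds shown here, the steps that bear on it, a 30-fold lower number from compound 1 to compound 3 (1.47 log units; beyond the scatter) and a 39-fold lower number from compound 2 to compound 3 (1.59 log units; beyond the scatter), are large, but each exchanges the fluoro itself, which compound 4 keeps. The step that only removes a methoxy, a 1.3-fold higher number from compound 1 to compound 2 (0.12 log units; within the scatter), lay within the scatter, so the methoxy on its own seems to matter little. Compound 4 is therefore expected to move only slightly, by a 1.3-fold higher number from compound 3 to compound 4 (0.12 log units; within the scatter), with the risk leaning toward a higher number. The estimate for compound 4 is 400 nM, in the range 150 nM to 1500 nM.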

Compound 4, half-maximal inhibitory concentration: 15500 nM
For compound 4 the middle estimate is 39-fold (1.59 log units) below the measured one, outside the stated range (above it).
By their numbers in this assay, from the lowest: compound 3; then compounds 1, 2 and 4 (each within the scatter of the next).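

In this assay, a methoxy on the aromatic carbon ortho to the fluoro group is far from a neutral addition: a 52-fold higher number from compound 3 to compound 4 (1.71 log units; beyond the scatter). The 4-fluoro-3-methoxyphenyl arm instead falls in with the methoxy-bearing arms, a 1.3-fold higher number from compound 2 to compound 4 (0.12 log units; within the scatter) and a 1.7-fold higher number from compound 1 to compound 4 (0.24 log units; within the scatter), so among these four compounds the low number belongs to the 4-fluorophenyl arm alone. The effect of this methoxy depends on the arm that carries it: the same change on two cores in this assay, a 1.3-fold higher number (0.12 log units; within the scatter) from compound 1 to compound 2 and a 52-fold lower number (1.71 log units; beyond the scatter) from compound 4 to compound 3, 69-fold (1.84 log units) apart, beyond the scatter of two such steps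

Still open, as far as these compounds go, is whether a group smaller than methoxy at this position, such as hydroxyl or chloro, keeps the number of compound 3, or whether only hydrogen does.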